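Notes on the aryl swap from compound 2 to compound 3

The source may report more compounds than this note shows. Statements on the series, on what has been measured and on what is new or still open speak of the compounds shown alone.

Values in a functional assay on MCF7 cells (Homo sapiens) for antiproliferative activity, read by MTT assay, with stated times of 24 h and 72 h; a higher number here means a weaker inhibitor, a lower number a stronger inhibitor:
compound 1 `COc1cc([C@@H]2[C@H](Oc3ccccc3)C(=O)N2c2cc(OC)c(OC)c(OC)c2)cc(OC)c1OC`: 29000 nM
compound 2 `COc1cc(N2C(=O)[C@@H](Oc3ccccc3)[C@H]2c2cccc3ccccc23)cc(OC)c1OC`: 53000 nM

Only these two numbers exist so far in this assay. Among the compounds with values here, compound 2 gives 53000 nM, which lies within the scatter of the only other measured compound, so the pair sets one level rather than a ranking.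

The next structure is compound 3 `COc1cc(N2C(=O)[C@@H](Oc3ccccc3)[C@H]2c2ccc(N=[N+]=[N-])cc2)cc(OC)c1OC`. Its difference from compound 2 is 4-azidophenyl in place of naphthalen-1-yl on a saturated ring carbon. Within the data shown here, the 4-azidophenyl group has no measured precedent, so the expectation rests on a single comparison.

That comparison is at the same saturated ring carbon, where naphthalen-1-yl replaced 3,4,5-trimethoxyphenyl, and it gave a 1.8-fold higher number from compound 1 to compound 2 (0.26 log units; within the scatter). One exchange of large groups at this place therefore left the number within the scatter. One step is a thin base, and it gives no direction for the new group. No step beyond the scatter is expected in this assay, although the range is kept wide.

The estimate corresponds to an expected 1.3-fold lower number from compound 2 to compound 3 (0.12 log units; within the scatter).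

For compound 3 the estimated value is 40000 nM, with an expected range of 14000 nM to 110000 nM.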

Compound 3, half-maximal inhibitory concentration: 23000 nM
For compound 3 the middle estimate is 1.7-fold (0.24 log units) above the measured one, within the range that was stated.
By their numbers in this assay, from the lowest: compounds 3, 1 and 2 (each within the scatter of the next, the first and the last beyond it).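

In this assay, within the data shown here, 4-azidophenyl in place of naphthalen-1-yl on the saturated ring carbon gives a 2.3-fold lower number from compound 2 to compound 3 (0.36 log units; beyond the scatter) and is the first step to pass the scatter, though only modestly, so the number at this position does respond to the group it carries. Set against 3,4,5-trimethoxyphenyl at the same carbon, the same group gives a 1.3-fold lower number from compound 1 to compound 3 (0.10 log units; within the scatter), which places compound 1 at one level with compound 3; the only separation among the three compounds is therefore between the two ends, compound 2 and compound 3, with compound 1 within the scatter of both. Nothing available on these compounds speaks to the origin of this separation.

From the compounds shown here alone, it remains open whether the step follows the azido group itself or the change from two aromatic rings to one, a question that a plain phenyl or a 4-aminophenyl on the same ring carbon would address. Also open, going by these compounds, is how far the number moves when the phenoxy group gives way to an amine or a longer alkyl chain, with the aryl group held constant.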